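Swapping an Oxetane for Methyl on the Pyrazole Nitrogen

This account rests on a few compounds, and the source may have more. Where it says the series, first, only, none or still open, it means among the compounds named here.

Compound 1 `Cc1nn(C2COC2)cc1Nc1nc(N)c2c(C#N)c(N3CCC[C@H]3C)n(C)c2n1`: 38 nM
Compound 2 `Cc1c(Nc2nc(N)c3c(C#N)c(N4CCC[C@H]4C)n(C)c3n2)cnn1CC(C)(C)O`: 43 nM

In an assay on isolated protein for inhibition of Leucine-rich repeat serine/threonine-protein kinase 2 (Homo sapiens), read by TR-FRET and LanthaScreen, with stated times of 50 min and 30 min, in the presence of a further agent that is not named here (a higher number here means a weaker inhibitor, a lower number a stronger inhibitor), compound 1 gives 38 nM and compound 2 gives 43 nM; these two numbers lie within the usual scatter, so neither compound can be called the stronger. Compound 3 `Cc1nn(C)cc1Nc1nc(N)c2c(C#N)c(N3CCC[C@H]3C)n(C)c2n1` differs from compound 1 by one change, (methyl in place of oxetan-3-yl on an aromatic nitrogen), methyl in place of oxetan-3-yl on an aromatic nitrogen. Compound 2 carries a different group on that same nitrogen and still gives 43 nM, which suggests that this position tolerates change. The step of a 1.3-fold higher number from compound 1 to compound 3 (0.12 log units; within the scatter) is therefore expected to stay within the scatter. Compound 3 is estimated at 50 nM, in the range 20 nM to 130 nM.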

Compound 3, half-maximal inhibitory concentration: 38 nM
For compound 3 the middle estimate is 1.3-fold (0.12 log units) above the measured one; low and high end bracket the measured number.
By their numbers in this assay, from the lowest: compounds 1, 3 and 2 (each within the scatter of the next).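

In this assay there is no change at the digits printed from compound 1 to compound 3 (within the scatter) on replacing oxetan-3-yl with methyl. The four-membered ring and its oxygen, a hydrogen-bond acceptor, can therefore give way on this aromatic nitrogen to a single carbon with no difference that can be read, so neither the ring nor that acceptor is needed for this level of inhibition.

From the compounds shown here alone, how this nitrogen would respond to an amine, a carboxylic acid or a longer chain such as n-butyl remains open. No measurement is available to explain the result.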